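Biphenyl amide with a pyrimidinyl nitrogen substituent

The source may hold more compounds than are shown below. What is called first, only, known or untested is meant among the compounds shown, and "the series" means these compounds.

Measured compounds:
Compound 1 `O=C(NCc1ccccc1)c1ccccc1-c1ccccc1`: 7600 nM
Compound 2 `COc1ccc(OCCCCCN2CCCC(COC(=O)c3ccccc3N3C(=O)CC(C)C3=O)C2)cc1OC`: 2000000 nM

In an in vitro functional assay on HEK ts201 cells for antagonist activity at Neuronal acetylcholine receptor; alpha3/beta4 (Homo sapiens), read by fluorescence and calcium flux (on this read-out lower numbers stand for stronger inhibition and higher numbers for weaker inhibition), compound 1 gives 7600 nM, the lower of the two numbers recorded. Compound 2, a structurally unrelated ester, gives 2000000 nM in this assay, a number far higher than that of compound 1 and well beyond the scatter, so compound 1 is the stronger inhibitor of the pair.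

Compound 3 `O=C(Nc1ccncn1)c1ccccc1-c1ccccc1` keeps the core of compound 1 and differs from it in one place: pyrimidin-4-yl in place of benzyl on an amide-type nitrogen. Among the compounds with values here, no measured pair isolates this kind of change, so the expectation rests on compound 1 alone. A step of modest size toward a higher number is expected, a 2.0-fold higher number from compound 1 to compound 3 (0.30 log units; within the scatter), though a result within the scatter would not be surprising. Compound 3 is estimated at 15000 nM in this assay, within a range from 4000 nM to 60000 nM.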

Compound 3, half-maximal inhibitory concentration: 39600 nM
Beside the measured number, compound 3's estimate is 2.6-fold (0.42 log units) below it; the measured number falls inside the stated range.
By their numbers in this assay, from the lowest: compound 1; then compound 3; then compound 2.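

In this assay, the group on the amide-type nitrogen proves to matter: pyrimidin-4-yl in place of benzyl gives a 5.2-fold higher number from compound 1 to compound 3 (0.72 log units; beyond the scatter) and so weakens inhibition, showing that this position does not take the change without cost. The swap replaces a ring of carbon only with a ring holding two hetero atoms and two hydrogen-bond acceptors, but this single step cannot show which difference carries the shift. Nothing measured here explains the step.

From the compounds shown here alone, whether a phenyl or a pyridin-4-yl group on the same nitrogen would stand nearer compound 1 or compound 3 remains open, so the part played by the ring nitrogens cannot yet be separated from that of the benzyl carbon. Also open, going by these compounds, is whether the same swap would have a similar effect with a methoxy group added to the core.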